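The source may hold more compounds than are shown below. What is called first, only, known or untested is meant among the compounds shown, and "the series" means these compounds.

In a functional assay on HepG2 cells (Homo sapiens) for inhibition, read by MTT assay, with a stated time of 48 h (a lower number here means a stronger inhibitor, a higher number a weaker inhibitor), compound 3 `CCOC(=O)C1=C(N/N=C(/Br)c2ccccc2)Nc2[nH]nc(C)c2C1c1ccc(N(C)C)cc1` gives 72000 nM and compound 2 `CCOC(=O)C1=C(N/N=C(/C(=O)Br)c2ccc(Br)cc2)Nc2[nH]nc(C)c2C1c1ccc(N(C)C)cc1` gives 65000 nM, a pair within the scatter (a 1.1-fold higher number from compound 2 to compound 3 (0.04 log units; within the scatter)). Compound 1 `CCOC(=O)C1=C(N/C=N/c2cccnc2Cl)Nc2[nH]nc(C)c2C1c1ccc(N(C)C)cc1` gives 4890 nM, well apart from both, as shown by a 15-fold higher number from compound 1 to compound 3 (1.17 log units; beyond the scatter) and a 13-fold higher number from compound 1 to compound 2 (1.12 log units; beyond the scatter). Compound 4 `CCOC(=O)C1=C(N/C=N/c2ccc([N+](=O)[O-])cc2)Nc2[nH]nc(C)c2C1c1ccc(N(C)C)cc1` departs from compound 3 through (a group of 11 heavy atoms (7 carbon, 2 nitrogen, 2 oxygen; one six-membered aromatic ring of carbon only) in place of a group of 9 heavy atoms (7 carbon, 1 nitrogen, 1 bromine; one six-membered aromatic ring of carbon only), on an amine nitrogen). Compound 4 shares with compound 1 the link between the amine nitrogen and the aromatic ring, although the rings differ, so a large fall in this assay is expected, resting on a 15-fold higher number from compound 1 to compound 3 (1.17 log units; beyond the scatter), and probably not the whole of it. The expected change is an 8.0-fold lower number from compound 3 to compound 4 (0.90 log units; beyond the scatter). For compound 4 the estimated value is 9000 nM, with an expected range of 3000 nM to 30000 nM.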

Compound 4, half-maximal inhibitory concentration: 50900 nM
The estimate for compound 4 lay 5.7-fold (0.75 log units) below the measured number, and the stated range ends below it.
By their numbers in this assay, from the lowest: compound 1; then compounds 4, 2 and 3 (each within the scatter of the next).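

In this assay the shared link between the amine nitrogen and the aromatic ring does not alone bring a compound to the level of compound 1, since a 1.4-fold lower number from compound 3 to compound 4 (0.15 log units; within the scatter) and a 1.3-fold lower number from compound 2 to compound 4 (0.11 log units; within the scatter) are both within the scatter. With that link held constant, the ring on the double-bonded nitrogen still matters, as a 10-fold higher number from compound 1 to compound 4 (1.02 log units; beyond the scatter) shows on going from 2-chloropyridin-3-yl to 4-nitrophenyl. Nothing available explains this difference.

As far as these compounds go, whether the ring nitrogen, the chlorine or their combination sets the level of compound 1 remains open. A pyridin-3-yl without chlorine or an unsubstituted phenyl on that nitrogen would begin to separate these.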